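The compounds below may be only part of what the source reports. "The series", "measured", "known", "first", "only" and "open" are said of these compounds alone.

Measured in an in vivo ADME assay on the whole organism for pharmacokinetics, with Rattus norvegicus as the target; on this read-out higher numbers stand for higher oral bioavailability and lower numbers for lower oral bioavailability:
- compound 1 `Fc1cnccc1-c1cc(-c2ccc(F)c(-c3ncccc3F)c2)cnn1`: 5%
- compound 2 `Fc1cnc(-c2cc(-c3cnnc(-c4c(F)cncc4F)c3)ccc2F)c(F)c1`: 50%

Of these two, compound 1 holds the lower number, and compound 2 lies higher by a gap beyond the usual scatter. Still unmeasured is compound 3 `Fc1cnc(-c2cc(-c3ccc(F)c(-c4ncccc4F)c3)cnn2)c(F)c1`. Relative to compound 1, it has 3,5-difluoropyridin-2-yl in place of 3-fluoropyridin-4-yl on an aromatic carbon. Among the compounds with values here, no measured pair differs in one place only, so the data give no direct guide to this change. Compound 2, at 50%, also carries a 3,5-difluoropyridin-2-yl group, but it differs from compound 3 elsewhere too, which makes it only a weak pointer. An upward step beyond the scatter in this assay is expected on that basis, with low confidence. The expected change is a number 25 percentage points higher from compound 1 to compound 3 (beyond the scatter). For compound 3 the estimate is 30%, within an expected range of 10% to 60%.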

Compound 3, oral bioavailability: 100%
Compound 3: middle estimate off by 70 percentage points, on the low side; measured number outside the range, above it.
By their numbers in this assay, from the lowest: compound 1; then compound 2; then compound 3.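

In this assay, within the data shown here, 3,5-difluoropyridin-2-yl in place of 3-fluoropyridin-4-yl on an aromatic carbon next to the ring nitrogen gives a number 95 percentage points higher from compound 1 to compound 3 (beyond the scatter) and is the only single-place comparison so far. This position is therefore shown to be one where the choice of pyridine group alone can move oral bioavailability, while the counts of hydrogen-bond donors and acceptors and the net charge of the group stay the same. Nothing measured here speaks to the origin of the step.

Among these compounds, the single step cannot separate the added fluorine from the changed attachment of the pyridine ring, and it does not show whether the gain carries over to other cores. Also open, on these data alone, is how an amine or a methoxy group on this pyridine ring would read in this assay at this position.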